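The source may report more compounds than this note shows. Statements on the series, on what has been measured and on what is new or still open speak of the compounds shown alone.

For the measured compounds named here, compound 2 `CC(C)(C)NC(=O)N1CCC[C@H]1C(=O)N1CCC(NS(=O)(=O)c2cc(S(=O)(=O)c3ccccc3)ccc2C(F)(F)F)CC1` gives 20 nM in an assay on isolated protein for binding affinity to secreted frizzled-related protein 1 (Homo sapiens), read by fluorescence (on this read-out higher numbers stand for weaker inhibition and lower numbers for stronger inhibition), the lower of the two numbers measured so far, while compound 1 `O=C(CN1CCNCC1)N1CCC(NS(=O)(=O)c2cc(S(=O)(=O)c3ccccc3)ccc2C(F)(F)F)CC1` gives 140 nM. Going by the values given here, the one measured step, a 7.0-fold lower number from compound 1 to compound 2 (0.85 log units; beyond the scatter), replaced the whole group on that carbonyl carbon and so does not isolate the change now in question. Compound 3 `CN(C)C(=O)N1CCC[C@H]1C(=O)N1CCC(NS(=O)(=O)c2cc(S(=O)(=O)c3ccccc3)ccc2C(F)(F)F)CC1` differs from compound 2 by dimethylamino in place of (tert-butyl)amino on a carbonyl carbon. Among the compounds with values here, no measured step tests this change on its own, so the expected step is a 1.8-fold higher number from compound 2 to compound 3 (0.24 log units; within the scatter), small and uncertain in direction. Compound 3 is estimated at 35 nM, with a range from 12 nM to 100 nM.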

Compound 3, half-maximal inhibitory concentration: 30 nM
Compound 3: the middle estimate sits 1.2-fold (0.07 log units) above what was measured; measured number inside the range.
By their numbers in this assay, from the lowest: compounds 2 and 3 (each within the scatter of the next); then compound 1.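

Putting dimethylamino in place of (tert-butyl)amino on this carbonyl carbon gives a 1.5-fold higher number from compound 2 to compound 3 (0.18 log units; within the scatter), so in this pair, losing the hydrogen-bond donor counted on (tert-butyl)amino does not move the number beyond the scatter. The advantage over the (piperazin-1-yl)methyl group also remains, with a 4.7-fold lower number from compound 1 to compound 3 (0.67 log units; beyond the scatter), so it does not rest on the (tert-butyl)amino group alone. Nothing available explains these results. Still open, from the compounds shown here alone, is whether a plain amino group or a methoxy group on this carbonyl carbon would keep the number in the same range.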